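The compounds below may be only part of what the source reports. "The series", "measured", "known", "first", "only" and "open" are said of these compounds alone.

Measured in an ADME assay on HepG2 cells (Homo sapiens) for cytotoxicity, read by MTT assay, with a stated time of 72 h; a lower number here means that less compound is tolerated, a higher number that more compound is tolerated:
compound 1 `O=[N+]([O-])c1c(CS(=O)(=O)c2ccccc2)nc2c(-c3ccc(Cl)cc3)cc(Cl)cn12`: > 3900 nM, a limit
compound 2 `O=[N+]([O-])c1c(CS(=O)(=O)c2ccccc2)nc2c(-c3ccc(CO)cc3)cc(Cl)cn12`: 13100 nM

Among the measured compounds shown here, compound 2 is the only compound with a true number in this assay. Compound 1 stands at the limit of > 3900 nM in this assay, at which 1 of the 2 values shown sits.

Compound 3 `O=[N+]([O-])c1c(CS(=O)(=O)c2ccccc2)nc2c(-c3ccc(F)cc3)cc(Cl)cn12` differs from compound 2 by fluoro in place of hydroxymethyl on an aromatic carbon. For the measured compounds named here, the only measured step bearing on this change is a step that the limit leaves unreadable from compound 1 to compound 2, which gives neither size nor direction. With compound 2 at 13100 nM as the sole anchor, no step beyond the scatter is expected. The estimated step is a 1.3-fold lower number from compound 2 to compound 3 (0.12 log units; within the scatter). Compound 3 is expected at 10000 nM, within 4000 nM to 30000 nM.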

Compound 3, half-maximal cytotoxic concentration: > 15600 nM
Compound 3 ended at the assay's limit (the forecaster's own chance of this, stated with the estimate: 40%); middle value at least 1.5-fold (0.19 log units) away from the limit.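

In this assay, fluoro on this aromatic carbon gives an at least 1.1-fold higher number from compound 2 to compound 3 (0.07 log units; that floor lies within the scatter). The value of compound 3, > 15600 nM, is a limit. On these data alone, the hydroxymethyl group is therefore not needed to keep the number at this level, a point compound 2 could not show alone, although the true size of the step remains unknown.

The steps from compound 1 to compound 2 and to compound 3 cannot be read, so chloro remains unplaced against both groups. As far as these compounds go, how an amine or a carboxylic acid at this position would read in this assay remains open.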